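Swapping Benzyl for 4-Ethylphenyl on the Shared Core

The source may hold more compounds than are shown below. What is called first, only, known or untested is meant among the compounds shown, and "the series" means these compounds.

Among the compounds with values here, compound 3 `C=C(Br)C(=O)Nc1cccc(-c2cn3nc(Cc4ccccc4)sc3n2)c1` gives 3000 nM in a functional assay on L1210 cells (Mus musculus) for inhibition, read by cell counting, with a stated time of 2 days (on this read-out higher numbers stand for weaker inhibition and lower numbers for stronger inhibition), the highest of the three numbers measured so far. Its nearest neighbour is compound 1 `C=C(Br)C(=O)Nc1cccc(-c2cn3nc(CCc4ccccc4)sc3n2)c1`, which gives 2200 nM, and the two sit within the scatter of each other. Compound 2 `C=C(Br)C(=O)Nc1cccc(-c2cn3nc(-c4ccc(Cl)cc4)sc3n2)c1` gives 1400 nM, and the step of a 2.1-fold higher number from compound 2 to compound 3 (0.33 log units; beyond the scatter) is beyond the scatter. Compound 4 `C=C(Br)C(=O)Nc1cccc(-c2cn3nc(-c4ccc(CC)cc4)sc3n2)c1` has not yet been measured. The change from compound 3 is 4-ethylphenyl in place of benzyl on an aromatic carbon. Within the data shown here, two measured steps bear on it. The step of a 2.1-fold higher number from compound 2 to compound 3 (0.33 log units; beyond the scatter) shows what happened when a ring bound directly to the core was replaced by benzyl; running that exchange backwards points to a somewhat lower number. The step of a 1.6-fold lower number from compound 1 to compound 2 (0.20 log units; within the scatter) shows that exchanging one ring-bearing group for another at the aromatic carbon stayed within the scatter. Among the measured compounds shown here, no measured pair compares 4-ethylphenyl with 4-chlorophenyl, so the effect of the ethyl group itself is unknown. A modest drop is therefore expected: a 2.0-fold lower number from compound 3 to compound 4 (0.30 log units; within the scatter). Compound 4 is estimated at 1500 nM, with a range from 700 nM to 3500 nM.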

Compound 4, half-maximal inhibitory concentration: 2200 nM
Compound 4: middle estimate off by 1.5-fold (0.17 log units), on the low side; measured number inside the range.
By their numbers in this assay, from the lowest: compounds 2, 1, 4 and 3 (each within the scatter of the next, the first and the last beyond it).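

In this assay, 4-ethylphenyl gives a 1.4-fold lower number from compound 3 to compound 4 (0.13 log units; within the scatter) and no change at the digits printed from compound 1 to compound 4 (within the scatter), so at this aromatic carbon it cannot be told apart from benzyl or phenethyl. Ethyl in place of chloro gives a 1.6-fold higher number from compound 2 to compound 4 (0.20 log units; within the scatter), the first step shown that keeps the phenyl ring and changes only the group it carries. A ring bound directly to the core therefore does not by itself set a compound apart from compound 3: compound 4 has such a ring and stays within the scatter of compound 3, while compound 2 lies beyond it.

Nothing available explains why these groups give such similar numbers. From the compounds shown here alone, it remains open whether an amine or a carboxylic acid on the phenyl ring, or a longer chain at this carbon, would move the number beyond the scatter.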